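Methylating the phenol in two related enone scaffolds

This account rests on a few compounds, and the source may have more. Where it says the series, first, only, none or still open, it means among the compounds named here.

The account concerns four compounds tested in a functional assay on Bel-7402 cells (Homo sapiens) for antiproliferative activity, read by MTT assay, with a stated time of 48 h; a higher number here means a weaker inhibitor of growth, a lower number a stronger inhibitor of growth. Compound 1 `COc1ccc(/C=C2\Cc3c(cc(OC)c(OC)c3OC)C2=O)cc1O` gives 307 nM. Compound 2 `COc1ccc(/C=C2\Cc3c(cc(OC)c(OC)c3OC)C2=O)cc1OC` gives 10500 nM. The change between them is methyl in place of hydrogen on an oxygen on an aromatic ring and the step it made was a 34-fold higher number from compound 1 to compound 2 (1.53 log units; beyond the scatter). Compound 3 `COc1cc2c(cc1O)C(=O)/C(=C/c1cc(OC)c(OC)c(OC)c1)C2` shares its atoms with compound 1 but joined differently; the difference between the two cores is not broken down here. For compound 3 this assay reports only a limit, > 10000 nM. Compound 4 `COc1cc2c(cc1OC)C(=O)/C(=C/c1cc(OC)c(OC)c(OC)c1)C2` has not been measured; it differs from compound 3 by methyl in place of hydrogen on an oxygen on an aromatic ring, the same change as from compound 1 to compound 2. Compound 3 already sits at the limit of > 10000 nM in this assay, at which 1 of the 3 values shown sits, so the step to compound 4 is expected to be a step that the limit leaves unreadable from compound 3 to compound 4 at most, with another limit likely. Compound 4 is therefore estimated to give about 40000 nM.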

Compound 4, concentration for 50% growth inhibition: > 10000 nM
Compound 4: a limit, no number; the forecaster's own chance of this, stated with the estimate: 80%; the middle value is on the limit's open side.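

In this assay, among these compounds, compound 3 and compound 4 both give a limit, not a number, so no step between them can be read: the limit of > 10000 nM in this assay, at which 2 of the 4 values shown sit. The compounds shown leave open whether hydroxy to methoxy changes anything in the core of compound 3, as it does in the core of compound 1.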